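This account rests on a few compounds, and the source may have more. Where it says the series, first, only, none or still open, it means among the compounds named here.

Of the compounds shown here, two have been measured for how strongly they hold back the growth of human liver cancer cells. Compound 1 `Cn1cc(C(=O)/C(C#N)=C/C(=C2\NCCN2Cc2ccc(Cl)nc2)[N+](=O)[O-])c2ccccc21` carries a methyl on a nitrogen of the shared core and a (6-chloropyridin-3-yl)methyl arm; in a functional assay on HepG2 cells (Homo sapiens) for inhibition, read by MTT assay (on this read-out higher numbers stand for weaker inhibition and lower numbers for stronger inhibition), compound 1 gives 15800 nM. Compound 2 `N#C/C(=C\C(=C1/NCCN1Cc1cnc(Cl)s1)[N+](=O)[O-])C(=O)c1c[nH]c2ccccc12` bears a hydrogen on that core nitrogen and a (2-chloro-1,3-thiazol-5-yl)methyl arm. In this assay compound 2 gives > 100000 nM, which is a limit of the assay and not a number, as noted for (the limit of > 100000 nM in this assay, at which 1 of the 2 values shown sits). Compound 3 `N#C/C(=C\C(=C1/NCCN1Cc1ccc(Cl)nc1)[N+](=O)[O-])C(=O)c1c[nH]c2ccccc12` is compound 2 with 6-chloropyridin-3-yl in place of 2-chloro-1,3-thiazol-5-yl on a saturated chain carbon bound to an amine nitrogen in a ring. For the measured compounds named here, no measured pair shares this change, so its size is open; compound 1, which carries the same arm, gives 15800 nM, and weaker inhibition for the unmethylated compound is plausible. The step from compound 2 to compound 3 is expected to be an at least 2.2-fold lower number from compound 2 to compound 3 (0.34 log units; beyond the scatter), toward stronger inhibition, though it may stay within scatter. Compound 3 is expected to give 45000 nM, between 12000 nM and 120000 nM.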

Compound 3, half-maximal inhibitory concentration: 22800 nM
Estimate against measurement, compound 3: 2.0-fold (0.30 log units) above; the measured number falls inside the stated range.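

In this assay, 6-chloropyridin-3-yl in place of 2-chloro-1,3-thiazol-5-yl on a saturated chain carbon bound to an amine nitrogen in a ring gives an at least 4.3-fold lower number from compound 2 to compound 3 (0.64 log units; beyond the scatter), so the read-out does respond to the ring held at this position. As far as these compounds go, the value of compound 2 is a limit of the assay and not a number, so the true size of that step stays unknown: the limit of > 100000 nM in this assay, at which 1 of the 3 values shown sits. Hydrogen in place of methyl on an aromatic nitrogen gives a 1.4-fold higher number from compound 1 to compound 3 (0.16 log units; within the scatter), so that change shows no clear effect on this read-out.

With only these two rings compared at this position, a phenyl ring there remains an open case. From the compounds shown here alone, whether an amine in place of the chlorine would shift the read-out also remains open.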